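The source may hold more compounds than are shown below. What is called first, only, known or untested is meant among the compounds shown, and "the series" means these compounds.

Compound 1 `Cc1cc(Nc2nc(NCc3ccc(F)cc3F)nc3ccccc23)n[nH]1` gives 200 nM in an assay for inhibition of high affinity nerve growth factor receptor (Homo sapiens), read by HTRF, with a stated time of 30 min, in the presence of a further agent that is not named here; on this read-out higher numbers stand for weaker inhibition and lower numbers for stronger inhibition. Compound 2 `Cc1cc(Nc2nc(NCc3cc(F)ccc3F)nc3ccccc23)n[nH]1` gives 7.5 nM in this assay. Compound 3 `Cc1cc(Nc2nc(NCc3ccc(F)c(F)c3)nc3ccccc23)n[nH]1` gives 74 nM in this assay.

Compound 1 stands at the highest of these three numbers: its nearest neighbour is compound 3, with a 2.7-fold lower number from compound 1 to compound 3 (0.43 log units; beyond the scatter), and the furthest is compound 2, with a 27-fold lower number from compound 1 to compound 2 (1.43 log units; beyond the scatter). Compound 4 `Cc1cc(Nc2nc(NCc3ccc(F)cc3F)nc3cc(C(F)(F)F)ccc23)n[nH]1` keeps the 2,4-difluorophenyl of compound 1 and alters the shared core instead: trifluoromethyl in place of hydrogen on an aromatic carbon. For the measured compounds named here, none of the measured steps touches this place. The changes a 27-fold lower number from compound 1 to compound 2 (1.43 log units; beyond the scatter), a 2.7-fold lower number from compound 1 to compound 3 (0.43 log units; beyond the scatter) and a 9.9-fold higher number from compound 2 to compound 3 (0.99 log units; beyond the scatter) all move fluorine about the difluorophenyl, so they give no guide to a trifluoromethyl on the core. With nothing to lean on, the expected step of no change at the digits printed from compound 1 to compound 4 (within the scatter) is none beyond the scatter. Compound 4 is therefore estimated at 200 nM, within 50 nM to 800 nM.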

Compound 4, half-maximal inhibitory concentration: 57 nM
Estimate against measurement, compound 4: 3.5-fold (0.55 log units) above, and the stated range covers the measured number.
By their numbers in this assay, from the lowest: compound 2; then compounds 4 and 3 (each within the scatter of the next); then compound 1.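

The position on the shared core, which the earlier fluorine moves left untouched, proves responsive: in this assay, trifluoromethyl in place of hydrogen on an aromatic carbon gives a 3.5-fold lower number from compound 1 to compound 4 (0.55 log units; beyond the scatter). A group of four heavy atoms is therefore accepted here with the 2,4-difluorophenyl kept, and the number falls rather than rises. Nothing available accounts for this gain.

On these data alone, whether the gain carries over to the 2,5-difluorophenyl of compound 2 remains open. So does whether an amine, a nitrile or a methoxy group at this carbon would act like trifluoromethyl.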